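Adding a Chloro Group: Expected Permeability of Compound 4

This account rests on a few compounds, and the source may have more. Where it says the series, first, only, none or still open, it means among the compounds named here.

Measured compounds and their values:
Compound 1, `CC(C)COc1ncc(-c2cn(C)c3cc(C(=O)NS(C)(=O)=O)ccc23)cc1Cl`, 216 nm/s
Compound 2, `CC(C)COc1ccc(-c2cn(C)c3cc(C(=O)NS(=O)(=O)C4CC4)c(F)cc23)cn1`, 254 nm/s
Compound 3, `CC(C)COc1ccc(-c2nn(C)c3cc(C(=O)NS(=O)(=O)C4CC4)c(F)cc23)cn1`, 100 nm/s

These three compounds share a common core and were measured in an ADME assay for permeability, using PAMPA, at pH 7.4; a higher number here means that the compound crosses the layer faster, a lower number that the compound crosses the layer more slowly. Compound 2 gives 254 nm/s, and compound 1 gives 216 nm/s; these two numbers lie within the usual scatter of one another, so no order between them can be read. Compound 3 gives 100 nm/s, which is beyond the scatter below the number for compound 2. No single-change step between any two of these compounds is available, so their differences cannot be tied to one structural change.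

Compound 4, `CC(C)COc1ncc(-c2cn(C)c3cc(C(=O)NS(=O)(=O)C4CC4)c(F)cc23)cc1Cl`, has not yet been measured. It differs from compound 2 in one place: chloro in place of hydrogen on an aromatic carbon. Compound 1 also carries a chloro group at this place, and its number in this assay sits close to that of compound 2, which suggests that such a change need not move the number far.

For compound 4 the step from compound 2 is expected to be small, a 1.1-fold higher number from compound 2 to compound 4 (0.04 log units; within the scatter), and not beyond the scatter. Compound 4 is therefore estimated at 280 nm/s, with a range from 150 nm/s to 520 nm/s.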

Compound 4, apparent permeability: 310 nm/s
Beside the measured number, compound 4's estimate is 1.1-fold (0.04 log units) below it, and the stated range covers the measured number.
By their numbers in this assay, from the lowest: compound 3; then compounds 1, 2 and 4 (each within the scatter of the next).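

In this assay, among the compounds shown here, the pair of compound 2 and compound 4 gives the first direct reading of this change, and the step is a 1.2-fold higher number from compound 2 to compound 4 (0.09 log units; within the scatter) for chloro in place of hydrogen on an aromatic carbon of the six-membered aromatic ring with 1 nitrogen, ortho to an isobutoxy group and two atoms from the ring nitrogen. Compound 1 could only hint at this, as it differs from compound 2 in more than one place, whereas here the chloro group is the only difference, and the two numbers cannot be told apart, so on this core the position takes a chloro group with no readable shift in the number. Nothing shown explains the size of this step, so this remains an observation from a single pair of compounds.

The compounds shown hold only hydrogen or chloro at this position, so it stays open whether a methoxy group, an amine or a carboxylic acid there would leave the number as close. On these data alone, it also stays open whether a chloro group at this position would give so small a step on the core of compound 3.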